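Swapping the urea substituent on a sulfonamide-linked piperidine

The source may hold more compounds than are shown below. What is called first, only, known or untested is meant among the compounds shown, and "the series" means these compounds.

Two compounds share a core in which a naphthalene sulfonamide carries a piperidine ring. Compound 1 `CCC(=O)N1CCC(NS(=O)(=O)c2ccc(NC(=O)c3ccccc3C)c3ccccc23)CC1` bears a propanoyl group on that ring nitrogen and, in an assay on L1.2 cells for binding affinity to C-C chemokine receptor type 8 (Homo sapiens) (on this read-out lower numbers stand for stronger inhibition and higher numbers for weaker inhibition), compound 1 gives 2.5 nM. Compound 2 `Cc1ccccc1C(=O)Nc1ccc(S(=O)(=O)NC2CCN(C(=O)NC(C)C)CC2)c2ccccc12` replaces the ethyl on the carbonyl carbon with isopropylamino, and in this assay compound 2 gives 77.7 nM. The step of a 31-fold higher number from compound 1 to compound 2 (1.49 log units; beyond the scatter) is the only one measured, and it leaves compound 2 as the highest of the two numbers, its nearest neighbour being compound 1.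

Compound 3 `Cc1ccccc1C(=O)Nc1ccc(S(=O)(=O)NC2CCN(C(=O)N3CCCCC3)CC2)c2ccccc12` changes compound 2 by piperidin-1-yl in place of isopropylamino on a carbonyl carbon. For the measured compounds named here, no measured step covers a swap between two urea-type substituents, so the step from compound 1 to compound 2 bears on it only loosely: it shows that this position can move the number a great deal. A change of moderate size in either direction is therefore plausible, and the expected step is a 1.9-fold lower number from compound 2 to compound 3 (0.29 log units; within the scatter). For compound 3 the estimated value in this assay is 40 nM, with a range from 8 nM to 200 nM.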

Compound 3, inhibition constant: 4.2 nM
Beside the measured number, compound 3's estimate is 9.5-fold (0.98 log units) above it; the whole stated range lies above it.
By their numbers in this assay, from the lowest: compounds 1 and 3 (each within the scatter of the next); then compound 2.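

In this assay, the swap to piperidin-1-yl gives a 19-fold lower number from compound 2 to compound 3 (1.27 log units; beyond the scatter), while the comparison with the ethyl group gives a 1.7-fold higher number from compound 1 to compound 3 (0.23 log units; within the scatter), which leaves those two compounds indistinguishable, so a nitrogen attached to this carbonyl carbon does not by itself bring the weaker number seen with isopropylamino. The swap makes two changes at once: it removes the one hydrogen-bond donor counted on isopropylamino and it brings in a ring, so this pair of compounds cannot separate the two changes. No available measurement explains the size of this step.

Open-chain diethylamino would help to separate these changes, since, like piperidin-1-yl, it has no hydrogen on the nitrogen attached to the carbonyl carbon but, unlike piperidin-1-yl, it has no ring. Cyclohexylamino would test the opposite combination, a ring together with that hydrogen, and pyrrolidin-1-yl or morpholin-4-yl would show whether the low number of compound 3 survives a change in the ring itself.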